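Losing the trifluoromethylphenyl group from the cinnamate-type ester

The compounds below may be only part of what the source reports. "The series", "measured", "known", "first", "only" and "open" are said of these compounds alone.

In an ADME assay on HepG2 2.2.15 cells (Homo sapiens) for cytotoxicity (a lower number here means that less compound is tolerated, a higher number that more compound is tolerated), compound 1 `CCOCC(=O)OCCc1c(-c2ccccc2Cl)c2cc(Cl)ccc2[nH]c1=O` gives 130000 nM and compound 2 `O=C(CCOc1ccccc1)OCCc1c(-c2ccccc2Cl)c2cc(Cl)ccc2[nH]c1=O` gives 46000 nM. Compound 3 `O=C(/C=C/c1ccc(C(F)(F)F)cc1)OCCc1c(-c2ccccc2Cl)c2cc(Cl)ccc2[nH]c1=O` gives > 1400000 nM, which is a limit and not a number. Compound 3 therefore sits at the limit of > 1400000 nM in this assay, at which 1 of the 3 values shown sits.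

Compound 4 `C/C=C/C=C/C(=O)OCCc1c(-c2ccccc2Cl)c2cc(Cl)ccc2[nH]c1=O` differs from compound 3 as follows: prop-1-en-1-yl in place of 4-(trifluoromethyl)phenyl on a double-bonded chain carbon bound to a double-bonded chain carbon. Read one bond further out, 2-(4-(trifluoromethyl)phenyl)ethenyl becomes penta-1,3-dien-1-yl.

For the measured compounds named here, two measured steps bear most directly on this change. Going by the values given here, both are large and both end at the only compound carrying 4-(trifluoromethyl)phenyl: an at least 10-fold higher number from compound 1 to compound 3 (1.03 log units; beyond the scatter) and an at least 30-fold higher number from compound 2 to compound 3 (1.48 log units; beyond the scatter). The two esters without that group stay much closer together, with a 2.8-fold lower number from compound 1 to compound 2 (0.45 log units; beyond the scatter), a modest step. Compound 4 also lacks the group, so it is expected to fall back towards compound 1 and compound 2 in this assay. A large move to a lower number is expected, estimated as an at least 9.3-fold lower number from compound 3 to compound 4 (0.97 log units; beyond the scatter). For compound 4 the estimated value is 150000 nM, with an expected range of 40000 nM to 900000 nM.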

Compound 4, half-maximal cytotoxic concentration: 440000 nM
Estimate against measurement, compound 4: 2.9-fold (0.47 log units) below; low and high end bracket the measured number.
By their numbers in this assay, from the lowest: compound 2; then compound 1; then compound 4. At a limit, above all of these: compound 3.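

In this assay, losing the 4-(trifluoromethyl)phenyl group does not return the ester to the level of the other two: the penta-1,3-dien-1-yl ester stays apart from them, with a 3.4-fold higher number from compound 1 to compound 4 (0.53 log units; beyond the scatter) and a 9.6-fold higher number from compound 2 to compound 4 (0.98 log units; beyond the scatter), so the higher numbers in this series are not confined to the compound carrying that group. The direct change gives an at least 3.1-fold lower number from compound 3 to compound 4 (0.50 log units; beyond the scatter), and this size is only a minimum. The value for compound 3 is a limit and not a number: the limit of > 1400000 nM in this assay, at which 1 of the 4 values shown sits.

The compounds shown leave open whether the higher number of compound 4 follows the double bonds of its side chain or simply the carbon chain itself. A saturated hexanoate ester and an ester with plain phenyl in place of 4-(trifluoromethyl)phenyl would separate these readings.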